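One Hydroxy Capped: From Compound 2 to Compound 3

The source may report more compounds than this note shows. Statements on the series, on what has been measured and on what is new or still open speak of the compounds shown alone.

Measured in a functional assay on COLO 205 cells (Homo sapiens) for cytotoxicity, read by MTT assay, with a stated time of 24 h; a lower number here means a stronger inhibitor of growth, a higher number a weaker inhibitor of growth:
- compound 1 `COc1ccc(/C=C/C(=O)c2ccc(OCC=C(C)C)cc2O)c(OC)c1OC`: > 100000 nM (a limit, not a number)
- compound 2 `COc1cc(/C=C/C(=O)c2ccc(OCC=C(C)C)cc2O)cc(OC)c1OC`: 96000 nM

Within the data shown here, compound 2 holds the only true number in this assay, so there is no second figure to rank it against. Compound 1 gives > 100000 nM, which is only a limit of the assay.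

The next compound is compound 3 `COc1cc(/C=C/C(=O)c2ccc(OCC=C(C)C)cc2OCC=C(C)C)cc(OC)c1OC`, which is compound 2 with a single change: 3-methylbut-2-en-1-yl in place of hydrogen on an oxygen on an aromatic ring. Put simply, a hydroxy becomes (3-methylbut-2-en-1-yl)oxy. Among the measured compounds shown here, no two measured compounds differ in just one place, so the size of such a step has not been seen here.

Compound 2 at 96000 nM already shows very weak growth inhibition. The expectation is therefore no change beyond the usual scatter in either direction, with a real chance that only a limit is reported. The expected step is a 1.1-fold lower number from compound 2 to compound 3 (0.03 log units; within the scatter). The estimated value for compound 3 is 90000 nM, with an expected range of 35000 nM to 180000 nM.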

Compound 3, concentration for 50% growth inhibition: 78000 nM
Beside the measured number, compound 3's estimate is 1.2-fold (0.06 log units) above it; measured number inside the range.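

In this assay, putting 3-methylbut-2-en-1-yl in place of the hydrogen of the hydroxy gives a 1.2-fold lower number from compound 2 to compound 3 (0.09 log units; within the scatter). Among these compounds, this is the first single-place step seen at this oxygen on the aromatic ring, and it shows that compound 3, which has lost that hydroxy and carries a second (3-methylbut-2-en-1-yl)oxy group, cannot be told apart from compound 2 in this test, so a free hydroxy at this place is not needed to keep the weak growth inhibition of compound 2. The reading comes from the weak end of the scale, close to the point where only a limit is reported: the limit of > 100000 nM in this assay, at which 1 of the 3 values shown sits.

The compounds shown leave open whether a small group on this oxygen, such as methyl, or a group of a different kind, such as a chain ending in an amine or a carboxylic acid, would move the number beyond the scatter. They also leave open whether any change at this place would count for more on a version of the shared core that starts from a much lower number in this assay.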